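Swapping Methoxy for Chloro in an Oxytocin Receptor Antagonist

The source may report more compounds than this note shows. Statements on the series, on what has been measured and on what is new or still open speak of the compounds shown alone.

Compound 1 `COc1ccccc1[C@H](C(=O)NC(C)C)N1C(=O)[C@@H](C2Cc3ccccc3C2)NC(=O)[C@H]1CC(C)C`: 31.6 nM
Compound 2 `COC(=O)c1ccccc1[C@@H](C(=O)NC(C)C)N1C(=O)[C@@H](C2Cc3ccccc3C2)NC(=O)[C@H]1CC(C)C`: 158 nM

In an assay on isolated protein for antagonist activity at Oxytocin receptor (Homo sapiens), read by FLIPR (a lower number here means a stronger inhibitor, a higher number a weaker inhibitor), compound 1 gives the lower of the two measured numbers, and compound 2 gives the higher one, a gap that lies beyond the usual scatter. Compound 3 `CC(C)C[C@@H]1C(=O)N[C@H](C2Cc3ccccc3C2)C(=O)N1[C@@H](C(=O)NC(C)C)c1ccccc1Cl` has not been measured yet. It differs from compound 1 in one place: chloro in place of methoxy on an aromatic carbon. Among the compounds with values here, no measured pair shows this change, so no step size can be read off. The step of a 1.3-fold higher number from compound 1 to compound 3 (0.10 log units; within the scatter) is expected to be small, within the usual scatter, with no clear direction. Compound 3 is therefore estimated at 40 nM, with a range from 12 nM to 130 nM.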

Compound 3, inhibition constant: 3.98 nM
For compound 3 the middle estimate is 10-fold (1.00 log units) above the measured one; the measured number lies below the stated range.
By their numbers in this assay, from the lowest: compound 3; then compound 1; then compound 2.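

Chloro in place of methoxy on this aromatic carbon, ortho to a large group, gives a 7.9-fold lower number from compound 1 to compound 3 (0.90 log units; beyond the scatter), so the number responds clearly to a swap of a single substituent at this position. This one step also makes compound 3 the lowest of the three compounds. No measurement at hand explains why the number falls.

On these data alone, a single swap shows no trend, so it remains open whether fluoro, bromo or methyl at the same place would match chloro. As far as these compounds go, whether the same swap would give a similar step on a different core also remains open.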